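Pentyloxy to benzyloxy on the shared core

The source may hold more compounds than are shown below. What is called first, only, known or untested is meant among the compounds shown, and "the series" means these compounds.

Compound 1 `Cc1[nH]c(=O)n(C)c1-c1ccc(CC(C)C)cc1` gives 7800 nM in a functional assay on brain (Rattus norvegicus, strain Wistar) for inhibition; a higher number here means a weaker inhibitor, a lower number a stronger inhibitor. For the measured compounds named here, compound 2 `CCCCCOc1ccc(-c2c(C)[nH]c(=O)n2C)cc1` gives 4500 nM in this assay; the two values lie within the scatter of each other, a 1.7-fold lower number from compound 1 to compound 2 (0.24 log units; within the scatter), so neither compound stands apart on the numbers so far. Compound 3 `Cc1[nH]c(=O)n(C)c1-c1ccc(OCc2ccccc2)cc1` differs from compound 2 in one place: phenyl in place of butyl on a saturated chain carbon bound to an oxygen on an aromatic ring. No measured step bears on an aromatic ring entering in place of a chain, and the only step shown, a 1.7-fold lower number from compound 1 to compound 2 (0.24 log units; within the scatter), is within the scatter, so compound 3 is expected close to compound 2 with a wide range. Compound 3 is estimated at 3000 nM, between 900 nM and 10000 nM. The expected step is a 1.5-fold lower number from compound 2 to compound 3 (0.18 log units; within the scatter).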

Compound 3, half-maximal inhibitory concentration: 6700 nM
Beside the measured number, compound 3's estimate is 2.2-fold (0.35 log units) below it, within the range that was stated.
By their numbers in this assay, from the lowest: compounds 2, 3 and 1 (each within the scatter of the next).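

With a 1.5-fold higher number from compound 2 to compound 3 (0.17 log units; within the scatter) in this assay the position on the saturated chain carbon bound to an oxygen on an aromatic ring takes phenyl in place of butyl without a step beyond the scatter. A six-membered aromatic ring and an open chain therefore read alike at this position, on this single pair. No measured evidence bears on this result.
Still open, as far as these compounds go, is whether an amine or a carboxylic acid at the end of this chain would give a step beyond the scatter. The same question stands for a substituted phenyl, such as 4-chlorophenyl, in place of phenyl.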